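The compounds below may be only part of what the source reports. "The series", "measured", "known", "first", "only" and "open" are said of these compounds alone.

Working notes on the series. The shared core is that of compound 1 `Cc1oc(=O)oc1COC(=O)c1cccc(NC(=O)[C@@H]2C[C@H](SC3=C(C(=O)O)N4C(=O)[C@H]([C@@H](C)O)[C@H]4[C@H]3C)CN2)c1`, with compound 2 `CC(C)OC(=O)c1cccc(NC(=O)[C@@H]2C[C@H](SC3=C(C(=O)O)N4C(=O)[C@H]([C@@H](C)O)[C@H]4[C@H]3C)CN2)c1` and compound 3 `CCOC(=O)c1cccc(NC(=O)[C@@H]2C[C@H](SC3=C(C(=O)O)N4C(=O)[C@H]([C@@H](C)O)[C@H]4[C@H]3C)CN2)c1` differing only in the ester part. In a physicochemical assay for metabolic stability, read by LC-MS, in phosphate buffer, with a stated time of 3 h, at pH 7.4, tested at 50 uM (a lower number here means that less of the compound is left, a higher number that more of the compound is left), compound 1 gives > 95%, which is a limit of the assay and not a number. In this assay compound 2 gives > 95%, again a limit. In this assay compound 3 gives > 95%, also a limit, so compound 3 stands at the same limit as the other two and no ranking among them can be read. The steps among the measured compounds are accordingly unreadable: a step that the two limits leave unreadable from compound 1 to compound 2, a step that the two limits leave unreadable from compound 1 to compound 3 and a step that the two limits leave unreadable from compound 2 to compound 3 tell nothing about size or direction, because of the limit of > 95% in this assay, at which 3 of the 3 values shown sit.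

Compound 4 `C[C@@H](O)[C@H]1C(=O)N2C(C(=O)O)=C(S[C@@H]3CN[C@H](C(=O)Nc4cccc(C(=O)OCC(F)(F)F)c4)C3)[C@H](C)[C@H]12` is the next member to be measured. Relative to compound 3 the change is trifluoromethyl in place of methyl on a saturated chain carbon bound to an oxygen next to a carbonyl group. The three measured steps all sit at the limit, so they bear on the new step only in that the ester part has so far tolerated every variation without a readable loss. Going by the values given here, with no measured step to scale against, the step from compound 3 to compound 4 is expected to be small, a number at least 3 percentage points lower from compound 3 to compound 4 (that floor lies within the scatter), and compound 4 is estimated at 92% in this assay, with a range from 78% to 99%.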

Compound 4, percent of the compound remaining: > 95%
Compound 4 was reported as a limit; the forecaster's own chance of this, stated with the estimate: 55%; middle value at least 3 percentage points away from the limit.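

In this assay compound 4 gives > 95%, a limit and not a number. The steps from compound 1, compound 2 and compound 3 to compound 4 cannot be read, because all the values sit together: the limit of > 95% in this assay, at which 4 of the 4 values shown sit. The compounds shown leave open whether any change in the ester part of the shared core lowers the percent of compound remaining.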